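Swapping Cyclopentyl for 2-Methoxyphenyl on an Amine Nitrogen

The source may report more compounds than this note shows. Statements on the series, on what has been measured and on what is new or still open speak of the compounds shown alone.

- compound 1 `CCCc1ccc(NC2=CC(=O)c3nc4n(c3C2=O)[C@H]2OC[C@@H](O)[C@H]2OC4)cc1` gives 1560 nM
- compound 2 `O=C1C=C(NC2CCCCC2)C(=O)c2c1nc1n2[C@H]2OC[C@@H](O)[C@H]2OC1` gives > 8000 nM (a limit, not a number)
- compound 3 `O=C1C=C(NC2CCCC2)C(=O)c2c1nc1n2[C@H]2OC[C@@H](O)[C@H]2OC1` gives > 8000 nM (a limit, not a number)

Compound 3 has no exact reading in a functional assay on MGC-803 cells (Homo sapiens) for inhibition, read by sulforhodamine B assay (on this read-out higher numbers stand for weaker inhibition and lower numbers for stronger inhibition), and carries only a limit (> 8000 nM). Compound 2 stands with it at the limit of > 8000 nM in this assay, at which 2 of the 3 values shown sit, and so the two cannot be ranked.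

Compound 4 `COc1ccccc1NC1=CC(=O)c2nc3n(c2C1=O)[C@H]1OC[C@@H](O)[C@H]1OC3` has 2-methoxyphenyl in place of cyclopentyl on an amine nitrogen. Among the compounds with values here, two measured steps bear on this change. Cyclopentyl in place of 4-propylphenyl gave an at least 5.1-fold higher number from compound 1 to compound 3 (0.70 log units; beyond the scatter) and cyclohexyl in place of 4-propylphenyl gave an at least 5.1-fold higher number from compound 1 to compound 2 (0.70 log units; beyond the scatter) as its counterpart.

Within the data shown here, compound 1 (1560 nM) is the only measured compound with an aromatic ring on that nitrogen, so a modest move in the opposite direction is expected, toward a lower number and stronger inhibition in this assay here. The expected change is an at least 2.6-fold lower number from compound 3 to compound 4 (0.42 log units; beyond the scatter) and it remains uncertain. For compound 4 the estimate is 3000 nM (expected range 1000 nM to 8000 nM).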

Compound 4, half-maximal inhibitory concentration: 1630 nM
Estimate against measurement, compound 4: 1.8-fold (0.26 log units) above; the range from low to high includes it.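

In this assay, the link between an aromatic ring on this amine nitrogen and stronger inhibition no longer rests on compound 1 alone: 2-methoxyphenyl in place of cyclopentyl gives an at least 4.9-fold lower number from compound 3 to compound 4 (0.69 log units; beyond the scatter), and in place of cyclohexyl it gives an at least 4.9-fold lower number from compound 2 to compound 4 (0.69 log units; beyond the scatter). The two aromatic groups carry different substituents and sit in different forms, 2-methoxyphenyl and 4-propylphenyl, yet the step between them is a 1.0-fold higher number from compound 1 to compound 4 (0.02 log units; within the scatter), so this assay does not separate them. Among these four compounds, both with an aromatic ring read stronger than both with a non-aromatic carbon ring, and none goes against this.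

Still open, on these data alone, is whether an unsubstituted phenyl or a pyridine ring on the same nitrogen would read like these two aromatic groups. The true size of the gap to the non-aromatic rings also stays unknown, since compound 2 and compound 3 carry only a limit: the limit of > 8000 nM in this assay, at which 2 of the 4 values shown sit.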